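Aminomethyl in place of a larger group on the shared core

The source may hold more compounds than are shown below. What is called first, only, known or untested is meant among the compounds shown, and "the series" means these compounds.

Among the compounds with values here, compound 1 `COc1ccc(-c2nc(/N=C(\N)N(C)C)sc2-c2ccc(OC)cc2)cc1` gives 4.8 uM in a functional assay (aorta) with Rattus norvegicus as the target (on this read-out lower numbers stand for an effect already at smaller amounts and higher numbers for an effect only at larger amounts of compound), the only number among the values shown. Compound 2 `COc1ccc(-c2nc(/N=C(\N)NC3CCCCC3)sc2-c2ccc(OC)cc2)cc1` reaches only a limit in this assay, > 100 uM. The step of an at least 20-fold higher number from compound 1 to compound 2 (1.31 log units; beyond the scatter) is large, and it rests on (the limit of > 100 uM in this assay, at which 1 of the 2 values shown sits). Compound 3 `COc1ccc(-c2nc(CN)sc2-c2ccc(OC)cc2)cc1` differs from compound 1 by a group of 2 heavy atoms (1 carbon, 1 nitrogen; no ring) in place of a group of 6 heavy atoms (3 carbon, 3 nitrogen; no ring), on an aromatic carbon. Within the data shown here, that single measured step is the only guide, and it alters the same aromatic carbon of the five-membered aromatic ring with 1 nitrogen and 1 sulfur; a weakening in this assay is therefore expected for compound 3, a 6.3-fold higher number from compound 1 to compound 3 (0.80 log units; beyond the scatter). Compound 3 is estimated at 30 uM, between 8 uM and 100 uM.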

Compound 3, concentration for half-maximal effect: 7.7 uM
Estimate against measurement, compound 3: 3.9-fold (0.59 log units) above, and the stated range ends above it.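

In this assay, aminomethyl on this aromatic carbon stands level with the larger group of compound 1, with a 1.6-fold higher number from compound 1 to compound 3 (0.21 log units; within the scatter), so the group of 6 heavy atoms is not required at this position. The cyclohexylamino group of compound 2 is the one that stands apart, with an at least 12-fold lower number from compound 2 to compound 3 (1.11 log units; beyond the scatter). The value of compound 2 is a limit: the limit of > 100 uM in this assay, at which 1 of the 3 values shown sits.

The compounds shown leave open whether the nitrogen of aminomethyl matters, as they give no reading for a methyl or hydroxymethyl group on this carbon. From the compounds shown here alone, how a longer chain such as aminoethyl would read here also remains open.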